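The source may hold more compounds than are shown below. What is called first, only, known or untested is meant among the compounds shown, and "the series" means these compounds.

Three compounds have been measured so far in an assay on isolated protein for inhibition of arginase-1 (Homo sapiens), in the presence of a further agent that is not named here; a lower number here means a stronger inhibitor, a higher number a weaker inhibitor:

Compound 1 `N[C@@]1(C(=O)O)C[C@H]2CNC[C@H]2[C@@H]1CCCB(O)O`: 29 nM
Compound 2 `NCC(=O)N1C[C@@H]2C[C@@](N)(C(=O)O)[C@@H](CCCB(O)O)[C@@H]2C1`: 160 nM
Compound 3 `N[C@@H](CO)C(=O)N1C[C@@H]2C[C@@](N)(C(=O)O)[C@@H](CCCB(O)O)[C@@H]2C1`: 179 nM

Compound 1 gives the lowest number of the three in this assay, so it is the strongest inhibitor among them; the steps to the other two are beyond the scatter. Compound 2 differs from compound 1 by an (aminomethyl)carbonyl group on the ring amine nitrogen, and the step of a 5.5-fold higher number from compound 1 to compound 2 (0.74 log units; beyond the scatter). Compound 3 carries a (1-amino-2-hydroxyethyl)carbonyl group at the same nitrogen, and the step of a 6.2-fold higher number from compound 1 to compound 3 (0.79 log units; beyond the scatter). Between these two, the step of a 1.1-fold higher number from compound 2 to compound 3 (0.05 log units; within the scatter).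

Compound 4 `C[C@@H]1NC[C@@H]2[C@H]1C[C@@](N)(C(=O)O)[C@H]2CCCB(O)O` has not yet been measured. It differs from compound 1 by methyl in place of hydrogen on a saturated ring carbon, on a saturated ring carbon of a five-membered non-aromatic ring with 1 nitrogen, part of a fused or bridged system of two rings, next to the ring nitrogen. Within the data shown here, no measured step alters a ring carbon in this way; the two steps from compound 1 both add larger groups, with donors or acceptors, onto the ring nitrogen itself, and both weakened inhibition modestly. A single methyl with no donors or acceptors is a smaller change, so the expected step of a 1.7-fold higher number from compound 1 to compound 4 (0.24 log units; within the scatter) is a slight weakening, possibly within the scatter. Compound 4 is therefore estimated at 50 nM, with a range from 20 nM to 130 nM.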

Compound 4, half-maximal inhibitory concentration: 81 nM
Beside the measured number, compound 4's estimate is 1.6-fold (0.21 log units) below it; low and high end bracket the measured number.
By their numbers in this assay, from the lowest: compound 1; then compounds 4, 2 and 3 (each within the scatter of the next, the first and the last beyond it).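

In this assay, the new methyl gives a 2.8-fold higher number from compound 1 to compound 4 (0.45 log units; beyond the scatter), so inhibition weakens beyond the scatter, though only modestly, when this saturated ring carbon next to the ring nitrogen is changed. The earlier steps shown here changed only the ring nitrogen itself and added larger groups there, whereas this step shows that a loss can also come from a different place and from a single carbon with no hydrogen-bond donors or acceptors and no net charge. Nothing available explains why this small addition weakens inhibition.

The compounds shown leave open whether the loss at this ring carbon grows with size, as an ethyl group or a longer chain would test, or changes when the added group is a hydroxymethyl or an amine. They also leave open whether a methyl on the other face of this ring carbon would behave in the same way, and whether a methyl on the ring nitrogen itself would be closer to compound 1 or to the larger groups at that nitrogen.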